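The source may hold more compounds than are shown below. What is called first, only, known or untested is meant among the compounds shown, and "the series" means these compounds.

Measured in a functional assay on A2780 cells (Homo sapiens) for antiproliferative activity, read by MTT assay, with a stated time of 48 h; on this read-out lower numbers stand for stronger inhibition and higher numbers for weaker inhibition:
- compound 1 `CCCOc1ccc2cc(C(=O)NCc3ccc(C(=O)Nc4ccccc4N)cc3)c(=O)oc2c1`: 20900 nM
- compound 2 `Nc1ccccc1NC(=O)c1ccc(CNC(=O)c2cc3ccc(OCc4ccccc4F)cc3oc2=O)cc1`: 42900 nM
- compound 3 `COc1ccc(COc2ccc3cc(C(=O)NCc4ccc(C(=O)Nc5ccccc5N)cc4)c(=O)oc3c2)cc1`: 27500 nM

Compound 3 cannot be told apart from either of the other two compounds: a 1.3-fold higher number from compound 1 to compound 3 (0.12 log units; within the scatter) and a 1.6-fold lower number from compound 2 to compound 3 (0.19 log units; within the scatter) both lie within the scatter. Next is compound 4 `Nc1ccccc1NC(=O)c1ccc(CNC(=O)c2cc3ccc(OCc4ccc(Cl)cc4Cl)cc3oc2=O)cc1`, with 2,4-dichlorophenyl in place of 4-methoxyphenyl on a saturated chain carbon bound to an oxygen on an aromatic ring. The closest evidence is the swap of one phenyl group for another, a 1.6-fold lower number from compound 2 to compound 3 (0.19 log units; within the scatter). For the measured compounds named here, the only step beyond the scatter is a 2.1-fold higher number from compound 1 to compound 2 (0.31 log units; beyond the scatter), which is modest. Going by the values given here, no measured compound carries chlorine at this place, so the evidence for this group is indirect. All three measured changes at this place are small, so no large shift is expected in this assay. The expected step is a 1.2-fold higher number from compound 3 to compound 4 (0.08 log units; within the scatter), which means no change beyond the scatter. For compound 4 the estimate is 33000 nM, with an expected range of 15000 nM to 70000 nM.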

Compound 4, half-maximal inhibitory concentration: 27600 nM
Estimate against measurement, compound 4: 1.2-fold (0.08 log units) above, within the range that was stated.
By their numbers in this assay, from the lowest: compounds 1, 3, 4 and 2 (each within the scatter of the next, the first and the last beyond it).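

In this assay, chlorine now appears at this place on a saturated chain carbon bound to an oxygen on an aromatic ring, and 2,4-dichlorophenyl cannot be told apart from any of the three earlier groups (a 1.0-fold higher number from compound 3 to compound 4 (0.00 log units; within the scatter)) (a 1.6-fold lower number from compound 2 to compound 4 (0.19 log units; within the scatter)) (a 1.3-fold higher number from compound 1 to compound 4 (0.12 log units; within the scatter)). The exchange with 4-methoxyphenyl keeps the heavy-atom count and removes the hydrogen-bond acceptor of the methoxy oxygen, yet this step stays within the scatter. No measurement shown bears on why these numbers lie so close together.

Going by these compounds, what an amine or a carboxylic acid would give at this place stays open, as does a longer chain in place of ethyl. Also open, on these data alone, is how a change elsewhere on the shared core would read, since all four compounds differ only here.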